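Moving the fluorine on the aryl ring of compound 2

A few compounds are considered here, and "the series" means these few. Any claim that something is new, unique, unknown or untested is made for them only; others in the source may bear on it.

Compound 1 `CC(C)(C)c1ccc(-n2nc(-c3ccc(C(F)(F)F)cc3O)nc2-c2ccccc2O)cc1` gives 81.1% in a functional assay on PC-12 cells (Rattus norvegicus) for cytotoxicity, read by MTT assay, with stated times of 2 h and 24 h, tested at 10 uM; on this read-out lower numbers stand for a weaker effect and higher numbers for a stronger effect at the one concentration tested. Compound 2 `Oc1cc(C(F)(F)F)ccc1-c1nc(-c2ccccc2O)n(-c2ccc(F)cc2)n1` gives 99.8% in this assay, and compound 3 `Oc1cc(C(F)(F)F)ccc1-c1nc(-c2ccccc2O)n(-c2ccc(Br)cc2)n1` gives 100%. Compound 2 stands second highest of the three: its nearest neighbour is compound 3, with a number 0.2 percentage points higher from compound 2 to compound 3 (within the scatter), while compound 1 lies furthest away, with a number 18.7 percentage points higher from compound 1 to compound 2 (beyond the scatter); compound 1 to compound 3 shows a number 18.9 percentage points higher from compound 1 to compound 3 (beyond the scatter). Compound 4 `Oc1cc(C(F)(F)F)ccc1-c1nc(-c2ccccc2O)n(-c2cccc(F)c2)n1` differs from compound 2 by 3-fluorophenyl in place of 4-fluorophenyl on an aromatic nitrogen. Within the data shown here, no measured step shifts a group to another ring position; the measured steps exchange one group for another on the same aromatic carbon, and the exchange from compound 2 to compound 3 stayed within the scatter. Compound 4 is therefore expected to move only a number 2.8 percentage points lower from compound 2 to compound 4 (within the scatter), giving an estimated 97% with a range from 83% to 100%.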

Compound 4, a percentage reported as activity, at one concentration (the size of the read-out at that concentration, not a potency): 98.3%
For compound 4 the middle estimate is 1.3 percentage points below the measured one; measured number inside the range.
By their numbers in this assay, from the lowest: compound 1; then compounds 4, 2 and 3 (each within the scatter of the next).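

Moving the fluorine, a change of ring position that no earlier step covered, gives in this assay a number 1.5 percentage points lower from compound 2 to compound 4 (within the scatter) and so leaves the read-out unchanged within the scatter. Compound 4 likewise sits close to the 4-bromophenyl compound, with a number 1.7 percentage points lower from compound 3 to compound 4 (within the scatter) as the step, but a number 17.2 percentage points higher from compound 1 to compound 4 (beyond the scatter) shows that it shares the gap from the 4-(tert-butyl)phenyl compound. Nothing shown explains these results. From the compounds shown here alone, what an amine or a carboxylic acid on this phenyl ring would do remains open. With a single concentration tested, the potencies of these compounds also remain open.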